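Carrying a Fluoro Addition Over to the Chloro Analogue

The compounds below may be only part of what the source reports. "The series", "measured", "known", "first", "only" and "open" are said of these compounds alone.

Compound 3 `O=S(=O)(/C=C/c1ccccn1)c1ccccc1Cl` is measured in an assay on U2OS cells for activation of nuclear factor erythroid 2-related factor 2 (Homo sapiens), read by beta-arrestin recruitment, with a stated time of 6 h (on this read-out lower numbers stand for an effect already at smaller amounts and higher numbers for an effect only at larger amounts of compound), where compound 3 gives 618 nM. Among the three numbers so far this stands second highest. Compound 1 `O=S(=O)(/C=C/c1ccccn1)c1ccccc1F` gives 1050 nM, which lies within the scatter of the value for compound 3, so no order can be claimed between them. Compound 2 `O=S(=O)(/C=C/c1ncccc1F)c1ccccc1F` gives 176 nM, and the gap from compound 3 to compound 2 is beyond the scatter.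

Compound 4 `O=S(=O)(/C=C/c1ncccc1F)c1ccccc1Cl` differs from compound 3 by fluoro in place of hydrogen on an aromatic carbon. The same exchange has been measured once: a 6.0-fold lower number from compound 1 to compound 2 (0.78 log units; beyond the scatter), a modest step beyond the scatter. The other measured step, a 1.7-fold lower number from compound 1 to compound 3 (0.23 log units; within the scatter), concerns a different exchange and is within the scatter, so it says little about the present change. Among the measured compounds shown here, because the one relevant precedent is a 6.0-fold lower number from compound 1 to compound 2 (0.78 log units; beyond the scatter), compound 4 is expected to show a step of a 5.9-fold lower number from compound 3 to compound 4 (0.77 log units; beyond the scatter) in this assay, toward a lower number. Compound 4 is therefore estimated at 105 nM, with a range from 45 nM to 250 nM.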

Compound 4, half-maximal effective concentration: 122 nM
The estimate for compound 4 lay 1.2-fold (0.07 log units) below the measured number; the measured number falls inside the stated range.
By their numbers in this assay, from the lowest: compounds 4 and 2 (each within the scatter of the next); then compounds 3 and 1 (each within the scatter of the next).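

In this assay, fluoro in place of hydrogen on an aromatic carbon, ortho to a large group and two atoms from the ring nitrogen, again gives a lower number, a 5.1-fold lower number from compound 3 to compound 4 (0.70 log units; beyond the scatter), so this change no longer rests on a single pair. The two steps agree in size: the same change on two cores in this assay, a 6.0-fold lower number (0.78 log units; beyond the scatter) from compound 1 to compound 2 and a 5.1-fold lower number (0.70 log units; beyond the scatter) from compound 3 to compound 4, 1.2-fold (0.07 log units) apart, within the scatter of two such steps. Chloro in place of fluoro stays within the scatter with the new fluoro present as well, a 1.4-fold lower number from compound 2 to compound 4 (0.16 log units; within the scatter), so that exchange gives no order on either core: the same change on two cores in this assay, a 1.7-fold lower number (0.23 log units; within the scatter) from compound 1 to compound 3 and a 1.4-fold lower number (0.16 log units; within the scatter) from compound 2 to compound 4, 1.2-fold (0.07 log units) apart, within the scatter of two such steps.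

The compounds shown carry only hydrogen or fluoro at this place, so it remains open whether chloro, methoxy or an amine there would give a step of similar size. From the compounds shown here alone, it also remains open whether the fluoro step would hold on any core beyond these two.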